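Removing the carbamoyl chain from compound 2

A few compounds are considered here, and "the series" means these few. Any claim that something is new, unique, unknown or untested is made for them only; others in the source may bear on it.

Compound 2 (`CCN(CC)CCNC(=O)Nc1sc(-c2ccc(Cl)cc2)c(-c2ccc(Cl)cc2)c1C(=O)NC1CC1`) stands without a single number in a functional assay on PC-3 cells (Homo sapiens) for inhibition, read by sulforhodamine B assay, with a stated time of 72 h (on this read-out lower numbers stand for stronger inhibition and higher numbers for weaker inhibition), where compound 2 reads "not determined" (no result reported) and nothing more. The structural change is hydrogen in place of (2-(diethylamino)ethyl)carbamoyl on a nitrogen on an aromatic ring and puts hydrogen in place of (2-(diethylamino)ethyl)carbamoyl on a nitrogen on an aromatic ring. This gives compound 3 (`Nc1sc(-c2ccc(Cl)cc2)c(-c2ccc(Cl)cc2)c1C(=O)NC1CC1`), which shares that amino group with compound 1 (`Nc1sc(-c2ccc(Cl)cc2)c(-c2ccc(Cl)cc2)c1C(=O)N1CCCCC1`). With no value for compound 2, no step size can be read from it. In this assay compound 1 gives 14300 nM and compound 3 is expected to differ from it by no more than the usual scatter, in neither direction. Compound 3 is estimated at 12000 nM (expected range 4000 nM to 35000 nM).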

Compound 3, half-maximal inhibitory concentration: 3680 nM
Compound 3: the middle estimate sits 3.3-fold (0.51 log units) above what was measured, outside the stated range (below it).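

In this assay, the amide on the carbonyl carbon matters with the amino group held constant: cyclopropylamino in place of piperidin-1-yl gives a 3.9-fold lower number from compound 1 to compound 3 (0.59 log units; beyond the scatter), a modest step. The step from compound 2 to compound 3 cannot be read, so this result says nothing about the (2-(diethylamino)ethyl)carbamoyl group on the nitrogen. No supporting data explain the change in compound 3.

Still open, from the compounds shown here alone, is how a morpholin-4-yl group or a longer alkylamino chain on that carbonyl carbon would read. Also open, going by these compounds, is how an acetyl group on the amino nitrogen would read.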